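The source may report more compounds than this note shows. Statements on the series, on what has been measured and on what is new or still open speak of the compounds shown alone.

Values measured so far in an ADME assay on HeLa cells (Homo sapiens) for cytotoxicity, read by MTT assay; on this read-out lower numbers stand for stronger inhibition and higher numbers for weaker inhibition:
- Compound 1 `COC(=O)CNC(=O)CCC(=O)Oc1ccc(C[C@H]2C(=O)OC[C@@H]2Cc2ccc(OC)c(OC)c2)cc1OC`: 179000 nM
- Compound 2 `COc1ccc(C[C@H]2COC(=O)[C@@H]2Cc2ccc(OCc3cn(-c4ccc(C)cc4)nn3)c(OC)c2)cc1OC`: >= 600000 nM (a limit of the assay)
- Compound 3 `COc1ccc(C[C@H]2COC(=O)[C@@H]2Cc2ccc(OC(=O)CCC(=O)N3CCCCC3)c(OC)c2)cc1OC`: 128000 nM

Compound 3, at 128000 nM, stands level with compound 1, as a 1.4-fold lower number from compound 1 to compound 3 (0.15 log units; within the scatter) shows. The limit belongs to compound 2, so only these two compounds carry actual numbers.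

Compound 4 `COc1ccc(C[C@H]2COC(=O)[C@@H]2Cc2ccc(OCc3cn(-c4ccccc4)nn3)c(OC)c2)cc1OC` is not yet measured in this assay. It departs from compound 3 on an oxygen on an aromatic ring, where (1-phenyl-1H-1,2,3-triazol-4-yl)methyl enters: a group of 12 heavy atoms (9 carbon, 3 nitrogen; one five-membered aromatic ring with 3 hetero atoms, one six-membered aromatic ring of carbon only) in place of a group of 12 heavy atoms (9 carbon, 1 nitrogen, 2 oxygen; one six-membered non-aromatic ring with 1 hetero atom), on an oxygen on an aromatic ring. Going by the values given here, the one measured step, a 1.4-fold lower number from compound 1 to compound 3 (0.15 log units; within the scatter), concerns a different exchange, so it gives no size for this one.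

Among the compounds with values here, the nearest guide is compound 2, the only measured compound that also holds a five-membered aromatic ring with 3 hetero atoms, and its >= 600000 nM is a limit. On that basis, the expected change is a 3.1-fold higher number from compound 3 to compound 4 (0.49 log units; beyond the scatter), toward weaker inhibition, and a report of only a limit would not surprise. The estimate for compound 4 is 400000 nM, with an expected range of 130000 nM to 900000 nM.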

Compound 4, half-maximal inhibitory concentration: 124000 nM
Estimate against measurement, compound 4: 3.2-fold (0.51 log units) above; the measured number lies below the stated range.
By their numbers in this assay, from the lowest: compounds 4, 3 and 1 (each within the scatter of the next). At a limit, above all of these: compound 2.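

In this assay, the (1-phenyl-1H-1,2,3-triazol-4-yl)methyl group on the oxygen on an aromatic ring reads level with both non-aromatic groups at this place, as a 1.0-fold lower number from compound 3 to compound 4 (0.01 log units; within the scatter) and a 1.4-fold lower number from compound 1 to compound 4 (0.16 log units; within the scatter) show. The five-membered aromatic ring with 3 hetero atoms therefore does not by itself set these compounds apart; the single methyl on an aromatic carbon does, with hydrogen in its place giving an at least 4.8-fold lower number from compound 2 to compound 4 (0.68 log units; beyond the scatter). Compound 2 stands at a limit of the assay: the limit of >= 600000 nM in this assay, at which 1 of the 4 values shown sits.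

Going by these compounds, it remains open whether a chlorine or a methoxy group on that same aromatic carbon would read like the methyl or like the hydrogen. On these data alone, it is also open whether a plain alkyl chain in place of the phenyl would keep the reading of compound 4.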